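A few compounds are considered here, and "the series" means these few. Any claim that something is new, unique, unknown or untested is made for them only; others in the source may bear on it.

Measured compounds:
compound 1, `O=C(CCc1nc2ccccc2c(=O)[nH]1)N/N=C/c1ccc(Cl)cc1`, gives 185000000 nM
compound 2, `COc1cc(/C=N/NC(=O)CCc2nc3ccccc3c(=O)[nH]2)cc(OC)c1O`, gives 105000000 nM
compound 3, `COc1cc(/C=N/NC(=O)CCCc2nc3ccccc3c(=O)[nH]2)ccc1O`, gives 115000000 nM

These three compounds share the same core and differ only in the ring at the far end and in the chain that carries it. In a physicochemical assay, read by spectrophotometry, with a stated time of 6 min (a lower number here means a stronger inhibitor, a higher number a weaker inhibitor), compound 1 gives 185000000 nM, the highest of the three numbers. Compound 3 gives 115000000 nM and compound 2 gives 105000000 nM; both lie within the usual scatter of compound 1, so the three cannot be told apart on these figures, and all three are weak inhibitors.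

Compound 4, `O=C(CCc1nc2ccccc2c(=O)[nH]1)N/N=C/c1ccccc1`, has not yet been measured in this assay. It differs from compound 1 in a single place: hydrogen in place of chloro on an aromatic carbon. Within the data shown here, no pair of measured compounds differs by this change alone, so there is no measured step to lean on. With the three measured values so close together, the expected step of a 1.1-fold higher number from compound 1 to compound 4 (0.06 log units; within the scatter) is small, most likely nothing beyond the scatter, perhaps leaning slightly toward a higher number. Compound 4 is therefore estimated at 210000000 nM, with a range from 95000000 nM to 470000000 nM.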

Compound 4, half-maximal inhibitory concentration: 265000000 nM
Beside the measured number, compound 4's estimate is 1.3-fold (0.10 log units) below it; measured number inside the range.
By their numbers in this assay, from the lowest: compounds 2, 3, 1 and 4 (each within the scatter of the next, the first and the last beyond it).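

In this assay, among these compounds, the 4-chlorophenyl to phenyl change gives a 1.4-fold higher number from compound 1 to compound 4 (0.16 log units; within the scatter) and so provides the first direct reading at this position, where the earlier compounds offered no pair differing in one place. The chloro on this aromatic carbon can give way to hydrogen with no difference that stands out from the usual scatter, so in this pair the chloro is not needed for the weak inhibition seen. No measurement at hand offers an explanation for this result.

Going by these compounds, what other groups would do at this same place, para to a large group, stays open: a single hydrogen-for-chloro pair says nothing about an amine, a methoxy group or a carboxylic acid there, and any of these could be read against the phenyl of compound 4. The compounds shown also offer no comparison that changes only the chain carrying the ring, so the effect of chain length on its own cannot be read from them.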